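The source may report more compounds than this note shows. Statements on the series, on what has been measured and on what is new or still open speak of the compounds shown alone.

Within the data shown here, compound 1 `O=[N+]([O-])c1cc(S(=O)(=O)C(Cl)(Cl)Br)ccc1NC1CCCCC1` is the only compound of this small set for which an assay on cells for inhibition of serine/threonine-protein kinase WNK1 (Homo sapiens), read by luminescence and Kinase-Glo, with a stated time of 2 h (a higher number here means a weaker inhibitor, a lower number a stronger inhibitor), returns a number: in it compound 1 gives 4000 nM. Compound 2 `CCS(=O)(=O)c1ccc(NC2CCCCC2)c([N+](=O)[O-])c1` gives only a limit of the assay, > 1000000 nM. Compound 3 `O=[N+]([O-])c1ccccc1NC1CCCCC1` gives likewise a limit, > 1000000 nM. Both of these values rest at the limit of > 1000000 nM in this assay, at which 2 of the 3 values shown sit. The step of an at least 250-fold higher number from compound 1 to compound 2 (2.39 log units; beyond the scatter) is therefore large, and so is the step of an at least 250-fold higher number from compound 1 to compound 3 (2.39 log units; beyond the scatter); between compound 2 and compound 3 the two limits leave the size of the step unreadable. Both measured steps alter the sulfonyl group of the core of compound 1. Compound 4 `O=[N+]([O-])c1cc(S(=O)(=O)C(Cl)(Cl)Br)ccc1NCc1ccco1` leaves that group untouched and changes the nitrogen on the aromatic ring instead: (furan-2-yl)methyl in place of cyclohexyl on a nitrogen on an aromatic ring. Among the measured compounds shown here, no measured step bears on the change from cyclohexylamino to ((furan-2-yl)methyl)amino, so the data give no direction for it. For compound 4 the expectation is therefore a step within the scatter, no change at the digits printed from compound 1 to compound 4 (within the scatter), and the value is estimated at 4000 nM, between 1000 nM and 16000 nM.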

Compound 4, half-maximal inhibitory concentration: 15000 nM
Compound 4: the middle estimate sits 3.8-fold (0.57 log units) below what was measured; the measured number falls inside the stated range.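

Among these compounds, this is the first step that leaves the sulfonyl group alone, and in this assay it gives a 3.8-fold higher number from compound 1 to compound 4 (0.57 log units; beyond the scatter). The nitrogen on an aromatic ring therefore responds to the group it carries, though far less sharply than the sulfonyl group did, and with the (bromo(dichloro)methyl)sulfonyl group kept, compound 4 still returns a readable number rather than a limit. Nothing measured here accounts for this step.

The compounds shown leave open how a benzyl group, a straight hexyl chain or a chain ending in an amine would fare on that nitrogen. They also leave open whether the step follows from losing the six-membered non-aromatic ring of carbon only or from gaining the oxygen of the five-membered aromatic ring.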